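Notes on the series: cyano on the benzyl ring

The source may hold more compounds than are shown below. What is called first, only, known or untested is meant among the compounds shown, and "the series" means these compounds.

Three members of the series have been measured in an assay on isolated protein for inhibition of DNA nucleotidylexotransferase (Homo sapiens), read by scintillation counting, with a stated time of 10 min; on this read-out higher numbers stand for weaker inhibition and lower numbers for stronger inhibition. Compound 1 `CCOC(=O)C(=O)CC(=O)/C=C/c1cn(-c2ccccc2)c2ccccc12` returns only a limit in this assay, > 40 uM. Compound 2 `CC(C)CCn1cc(/C=C/C(=O)CC(=O)C(=O)O)c2ccccc21` gives 16.3 uM in this assay. Compound 3 `CCOC(=O)C(=O)CC(=O)/C=C/c1cc(C(=O)c2ccccc2)cn1Cc1ccccc1` likewise returns only a limit in this assay, > 40 uM. Among the measured compounds shown here, compound 3 thus stands at the edge of what this assay resolves, and the only anchor for it is the limit of > 40 uM in this assay, at which 2 of the 3 values shown sit; no step between measured neighbours exists in the set, so the size of any single change is unknown from measurement.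

Compound 4 `CCOC(=O)C(=O)CC(=O)/C=C/c1cc(C(=O)c2ccccc2)cn1Cc1ccc(C#N)cc1` differs from compound 3 by one change, cyano in place of hydrogen on an aromatic carbon, para to a large group (cyano in place of hydrogen on an aromatic carbon); cut one bond further out, the change reads benzyl to 4-cyanobenzyl. Since compound 3 itself gives only a limit, neither direction nor magnitude can be drawn from measured steps, and the expected step from compound 3 to compound 4 is none beyond the scatter, a step that the limit leaves unreadable from compound 3 to compound 4. Compound 4 is accordingly estimated at 45 uM in this assay, with a range from 20 uM to 150 uM, and the most probable outcome is once more a limit rather than a number.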

Compound 4, concentration for 50% inhibition: > 40 uM
Compound 4: no number, only a limit (the forecaster's own chance of this, stated with the estimate: 75%); the middle value does not contradict the limit.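

No step can be read from compound 3 to compound 4, since each returns only a limit: the limit of > 40 uM in this assay, at which 3 of the 4 values shown sit.

Whether 4-cyanobenzyl in place of benzyl shifts inhibition at all in this assay, and in which direction or by how much, remains open from the compounds shown.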